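Dimethoxyphenyl in Place of Dichlorophenyl on the Ketone

This account rests on a few compounds, and the source may have more. Where it says the series, first, only, none or still open, it means among the compounds named here.

Of the compounds shown here, three that share one core have been tested in a functional assay on NCI/ADR-RES cells (Homo sapiens) for cytotoxicity, read by sulforhodamine B assay, with a stated time of 48 h, tested at 1 uM; a higher number here means a weaker effect of the compound at the concentration tested, a lower number a stronger effect. Compound 1 `COc1ccc(-c2cc(/C=C/C(=O)c3ccc(OC)c(OC)c3)[nH]n2)cc1` gives 91%, compound 2 `COc1cc(-c2cc(/C=C/C(=O)c3ccc(Cl)c(Cl)c3)[nH]n2)cc(OC)c1OC` gives 92%, and compound 3 `COc1ccc(-c2cc(/C=C/C(=O)c3ccc(N)cc3)[nH]n2)cc1` gives 85%. Compound 2 shows the highest of these three numbers, yet its gap to compound 1 and its gap to compound 3 both lie within the usual scatter, so no order among them can be claimed. Compound 4 `COc1ccc(C(=O)/C=C/c2cc(-c3cc(OC)c(OC)c(OC)c3)n[nH]2)cc1OC` is not yet measured. It differs from compound 2 in one place: 3,4-dimethoxyphenyl in place of 3,4-dichlorophenyl on a carbonyl carbon. All three measured compounds show only a weak effect at this concentration, and compound 1, which carries the same 3,4-dimethoxyphenyl on its carbonyl carbon, gives 91%. The step in this assay is therefore expected to stay within the scatter, estimated as a number 2 percentage points lower from compound 2 to compound 4 (within the scatter). Compound 4 is expected to give 90%, within a range from 80% to 98%.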

Compound 4, a percentage reported as activity, at one concentration (the size of the read-out at that concentration, not a potency): 90%
The estimate for compound 4 equals the measured number at the digits printed; the measured number falls inside the stated range.
By their numbers in this assay, from the lowest: compounds 3, 4, 1 and 2 (each within the scatter of the next).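

In this assay, with 3,4-dimethoxyphenyl in place of 3,4-dichlorophenyl on a carbonyl carbon, the step is a number 2 percentage points lower from compound 2 to compound 4 (within the scatter). Among the compounds shown here, this is the first direct comparison at this position, and it shows that this exchange, made on the core of compound 2, gives no change that can be claimed at this one concentration. No measurement shown explains this result.

Going by these compounds, it remains open whether a carboxylic acid on that phenyl ring, or a longer chain in its place, would give a step beyond the scatter. A single concentration also leaves the potencies of these compounds unknown.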